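The source may hold more compounds than are shown below. What is called first, only, known or untested is meant among the compounds shown, and "the series" means these compounds.

In a functional assay on MCF7 cells (Homo sapiens) for antiproliferative activity, read by MTT assay, with a stated time of 72 h (a lower number here means a stronger inhibitor, a higher number a weaker inhibitor), compound 1 `CN(c1ccccc1)S(=O)(=O)C1CC2OC1C(c1ccc(NC(=O)CCCCCCC(=O)O)cc1)=C2c1ccc(O)cc1` gives 63800 nM, compound 2 `CN(c1ccc(Cl)cc1)S(=O)(=O)C1CC2OC1C(c1ccc(NC(=O)CCCCCCC(=O)O)cc1)=C2c1ccc(O)cc1` gives 13700 nM, and compound 3 `CCN(c1ccc(C)cc1)S(=O)(=O)C1CC2OC1C(c1ccc(NC(=O)CCCCCCC(=O)O)cc1)=C2c1ccc(O)cc1` gives 42300 nM. Compound 3 therefore lies within the scatter of compound 1 and is weaker than compound 2, as a 3.1-fold higher number from compound 2 to compound 3 (0.49 log units; beyond the scatter) shows. Compound 4 `CCN(c1ccc(OC)cc1)S(=O)(=O)C1CC2OC1C(c1ccc(NC(=O)CCCCCCC(=O)O)cc1)=C2c1ccc(O)cc1` differs from compound 3 in one group: methoxy in place of methyl on an aromatic carbon. Within the data shown here, no measured step makes this exact swap. Chloro in place of hydrogen gave a modest change, a 4.7-fold lower number from compound 1 to compound 2 (0.67 log units; beyond the scatter), while the change that brought in the ethyl and methyl groups gave a 1.5-fold lower number from compound 1 to compound 3 (0.18 log units; within the scatter), within the scatter. No change beyond the scatter is therefore expected, and the estimated step is a 1.1-fold lower number from compound 3 to compound 4 (0.05 log units; within the scatter). Compound 4 is expected at 38000 nM, with an estimated range of 16000 nM to 80000 nM.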

Compound 4, half-maximal inhibitory concentration: 20300 nM
For compound 4 the middle estimate is 1.9-fold (0.27 log units) above the measured one, within the range that was stated.
By their numbers in this assay, from the lowest: compounds 2 and 4 (each within the scatter of the next); then compounds 3 and 1 (each within the scatter of the next).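

In this assay, methoxy in place of methyl on the aromatic carbon gives a 2.1-fold lower number from compound 3 to compound 4 (0.32 log units; beyond the scatter), showing that with ethyl on the sulfonamide nitrogen, a swap at this position alone can move the number beyond the scatter. The other two steps place compound 4 close to the chloro compound, with a 1.5-fold higher number from compound 2 to compound 4 (0.17 log units; within the scatter), and clear of the unsubstituted one, with a 3.1-fold lower number from compound 1 to compound 4 (0.50 log units; beyond the scatter). Nothing measured here explains why this swap moves the number. Still open, as far as these compounds go, is how an amine or a carboxylic acid at this position would read, and what the ethyl group contributes by itself.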